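Para-methyl on the 2-aryl ring of compound 1

The source may hold more compounds than are shown below. What is called first, only, known or untested is meant among the compounds shown, and "the series" means these compounds.

Measured compounds:
- compound 1, `COc1cc(-c2cccc3nc(-c4ccccc4)oc23)cc(OC)c1OC`: 6800 nM in a functional assay on NCI-H460 cells (Homo sapiens) for antiproliferative activity, read by MTT assay, with a stated time of 48 h; on this read-out higher numbers stand for weaker inhibition and lower numbers for stronger inhibition
- compound 2, `COc1ccc(-c2nc3cccc(-c4cc(OC)c(OC)c(OC)c4)c3o2)cc1`: 3500 nM
- compound 3, `COc1cc(-c2cccc3nc(-c4cccc(F)c4)oc23)cc(OC)c1OC`: 3300 nM

Among the three numbers, that of compound 1 is the highest. The gap to compound 2 is a 1.9-fold lower number from compound 1 to compound 2 (0.29 log units; within the scatter), the gap to compound 3 is a 2.1-fold lower number from compound 1 to compound 3 (0.31 log units; beyond the scatter). Between compound 2 and compound 3 the change is a 1.1-fold lower number from compound 2 to compound 3 (0.03 log units; within the scatter).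

Compound 4, `COc1cc(-c2cccc3nc(-c4ccc(C)cc4)oc23)cc(OC)c1OC`, is not yet measured. It differs from compound 1 by methyl in place of hydrogen on an aromatic carbon; cut one bond further out this reads phenyl to 4-methylphenyl. The two steps that bear on it are the ones from compound 1 to compound 2 and from compound 1 to compound 3, which each add one small group to the same ring and give a lowering that sits at or just beyond the scatter. The methyl is expected to behave like them, so a small lowering, or none beyond the scatter, is expected in this assay.

Compound 4 is thus estimated at 4000 nM, with a range of 2000 nM to 8000 nM. The step this estimate implies is a 1.7-fold lower number from compound 1 to compound 4 (0.23 log units; within the scatter), and it is expected to remain within or near the scatter.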

Compound 4, half-maximal inhibitory concentration: 1900 nM
Compound 4: the middle estimate sits 2.1-fold (0.32 log units) above what was measured; the measured number lies below the stated range.
By their numbers in this assay, from the lowest: compounds 4, 3, 2 and 1 (each within the scatter of the next, the first and the last beyond it).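

In this assay, phenyl to 4-methylphenyl gives a 3.6-fold lower number from compound 1 to compound 4 (0.55 log units; beyond the scatter), so one added methyl on this ring is enough to move the number clear of the scatter. The methyl cannot be separated from the other two substituted compounds, with a 1.8-fold lower number from compound 2 to compound 4 (0.27 log units; within the scatter) and a 1.7-fold lower number from compound 3 to compound 4 (0.24 log units; within the scatter), so methyl, methoxy and fluoro on this ring cannot be ranked against one another here. No supporting data bear on why the methyl gives this step.

Still open, as far as these compounds go, is whether the step depends on where the methyl sits, since it appears here only as 4-methylphenyl. Also open, from the compounds shown here alone, is how an ethyl, a tert-butyl, an amine or a carboxylic acid at the same carbon would read in this assay.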